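Swapping a saturated ring for a phenylsulfanyl group

This account rests on a few compounds, and the source may have more. Where it says the series, first, only, none or still open, it means among the compounds named here.

Measured compounds:
- compound 1, `C[C@H](O)[C@@H](CCc1cccc(Br)c1)n1cnc2c(N)ncnc21`: 0.6 nM
- compound 2, `C[C@H](O)[C@@H](CCC1CCCCC1)n1cnc2c(N)ncnc21`: 1.9 nM

In an assay on isolated protein for inhibition of adenosine deaminase (Bos taurus), with a stated time of 5 min (a higher number here means a weaker inhibitor, a lower number a stronger inhibitor), compound 2 stands with the highest number of the two measured compounds, with compound 1 giving the nearest value.

Compound 3, `C[C@H](O)[C@@H](CSc1ccccc1)n1cnc2c(N)ncnc21`, has not yet been measured. It differs from compound 2 by phenylsulfanyl in place of cyclohexylmethyl on a saturated chain carbon, two bonds along the chain from an aromatic nitrogen.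

Among the measured compounds shown here, the one measured step that bears on this is a 3.2-fold higher number from compound 1 to compound 2 (0.50 log units; beyond the scatter), where a six-membered aromatic ring gave way to a saturated one. Compound 3 brings an aromatic ring back, though the linker to it is changed and now holds a sulfur atom. On that basis a step toward a lower number is expected in this assay, of a size that may stay within the scatter: a 1.6-fold lower number from compound 2 to compound 3 (0.20 log units; within the scatter). Compound 3 is therefore estimated at 1.2 nM, within a range from 0.35 nM to 4 nM.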

Compound 3, inhibition constant: 135 nM
Compound 3: the middle estimate sits 110-fold (2.05 log units) below what was measured; measured number outside the range, above it.
By their numbers in this assay, from the lowest: compound 1; then compound 2; then compound 3.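

In this assay, this position proves far less forgiving than the earlier pair suggested: the change brings a 71-fold higher number from compound 2 to compound 3 (1.85 log units; beyond the scatter), whereas the swap of 3-bromophenyl for cyclohexyl gave only a 3.2-fold higher number from compound 1 to compound 2 (0.50 log units; beyond the scatter). Phenylsulfanyl and cyclohexylmethyl have the same number of heavy atoms, so a similar count of atoms at this place does not ensure a similar number in this assay. Nothing available explains the large loss.

Because this single step introduces both the sulfur and the aromatic ring, the compounds shown cannot separate the contribution of each. A cyclohexylsulfanyl group, which keeps the sulfur with a saturated ring, or a 2-phenylethyl group, which keeps the aromatic ring on an all-carbon chain, would help to tell the two apart.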